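The source may report more compounds than this note shows. Statements on the series, on what has been measured and on what is new or still open speak of the compounds shown alone.

In an in vitro ADME assay on microsomes from liver (Homo sapiens) for metabolic stability, tested at 5 uM (on this read-out lower numbers stand for a shorter-lived compound and higher numbers for a longer-lived compound), compound 1 `CC(C)(C)CCn1nc(-c2cccs2)c(O)c(C2=NS(=O)(=O)c3cc(NS(C)(=O)=O)ccc3N2)c1=O` gives > 1 h, which is a limit of the assay and not a number. Compound 2 `CCC(C)CCn1nc(-c2cccs2)c(O)c(C2=NS(=O)(=O)c3cc(NS(C)(=O)=O)ccc3N2)c1=O` gives > 1 h, again a limit. For the measured compounds named here, compound 3 `CS(=O)(=O)Nc1ccc2c(c1)S(=O)(=O)N=C(c1c(O)c(-c3cccs3)nn(CC3(C(F)(F)F)CCC3)c1=O)N2` gives 1 h, the only true number among the three.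

Compound 4 `CS(=O)(=O)Nc1ccc2c(c1)S(=O)(=O)N=C(c1c(O)c(-c3cccs3)nn(Cc3ccc(F)cc3)c1=O)N2` changes the group carried on the chain: 4-fluorophenyl in place of 1-(trifluoromethyl)cyclobutyl on a saturated chain carbon bound to an aromatic nitrogen. In words, 4-fluorophenyl stands in place of 1-(trifluoromethyl)cyclobutyl on a saturated chain carbon bound to an aromatic nitrogen.

Two measured steps alter this same place, a number no higher from compound 1 to compound 3 (the limit leaves the size open) and a number no higher from compound 2 to compound 3 (the limit leaves the size open), and neither has a readable size. Going by the values given here, none of the measured compounds carries 4-fluorophenyl, so these steps offer no size to carry over. The expectation therefore rests on compound 3 at 1 h, with no step beyond the scatter expected in this assay and no firm direction. The expected change is a 1.3-fold lower number from compound 3 to compound 4 (0.10 log units; within the scatter). The estimated half-life of compound 4 is 0.8 h, within an expected range of 0.4 h to 1.6 h.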

Compound 4, half-life: > 1 h
Compound 4: no number, only a limit; the forecaster's own chance of this, stated with the estimate: 35%; middle value at least 1.2-fold (0.09 log units) from the limit.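

In this assay, 4-fluorophenyl brings an aromatic ring to this saturated chain carbon, and this change gives a number no lower from compound 3 to compound 4 (the limit leaves the size open). Compound 4 gives > 1 h, which is a limit of the assay and not a number. The steps linking compound 4 with compound 1 and compound 2 cannot be read, and the compounds at this limit cannot be ranked against one another: the limit of > 1 h in this assay, at which 3 of the 4 values shown sit.

On these data alone, how far the half-life of compound 4 extends past the limit stays open, and so does whether its true difference from compound 3 goes beyond the usual scatter. Also open, as far as these compounds go, is how the half-life responds when this place carries a different kind of group, such as a pyridine ring, an amine or a carboxylic acid.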